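The compounds below may be only part of what the source reports. "The series", "measured", "known", "first", "only" and "open" are said of these compounds alone.

Measured so far, in a functional assay on KYSE-450 cells (Homo sapiens) for inhibition, read by MTT assay, with a stated time of 48 h; a higher number here means a weaker inhibitor, a lower number a stronger inhibitor:

- compound 1, `COc1ccc(CN(C(=O)C2CC2)c2cc(OC)c(OC)c(OC)c2)cc1O`, gives 80 nM
- compound 2, `C/C=C/C(=O)N(Cc1cc(OC)c(OC)c(OC)c1)c1ccc(OC)c(O)c1`, gives 9160 nM
- compound 3, `COc1ccc(CNc2cc(OC)c(OC)c(OC)c2)cc1[N+](=O)[O-]`, gives 16800 nM

Compound 1 stands lowest of the three numbers. Its gap to compound 2 and its gap to compound 3 both lie beyond the usual scatter of this assay, so compound 1 is the strongest inhibitor of the set as measured. Within the data shown here, no pair among the measured compounds differs in only one place, so no single-point step is available for comparison.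

Compound 4, `COCC(=O)N(Cc1ccc(OC)c(O)c1)c1cc(OC)c(OC)c(OC)c1`, keeps the core of compound 1 and alters only the acyl group on the amide-type nitrogen: methoxymethyl in place of cyclopropyl on a carbonyl carbon. The carbonyl and the rest of the molecule are unchanged. Whether an acyl change of this kind moves the number cannot be read from the measured compounds. Compound 4 is expected to remain in the potent range, with a modest step toward a weaker inhibitor, a 3.1-fold higher number from compound 1 to compound 4 (0.49 log units; beyond the scatter), as the best guess. Compound 4 is thus estimated at 250 nM, within a range of 60 nM to 1500 nM.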

Compound 4, half-maximal inhibitory concentration: 460 nM
The estimate for compound 4 lay 1.8-fold (0.26 log units) below the measured number; the range from low to high includes it.
By their numbers in this assay, from the lowest: compound 1; then compound 4; then compounds 2 and 3 (each within the scatter of the next).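

Among these compounds, this is the first single-point step: in this assay, methoxymethyl in place of cyclopropyl on a carbonyl carbon gives a 5.8-fold higher number from compound 1 to compound 4 (0.76 log units; beyond the scatter), so the number responds to the group at this position, though the step is only modest. The heavy-atom count stays the same across the change, while a three-membered ring of carbon only gives way to an open chain carrying one hydrogen-bond acceptor. No supporting measurement bears on why the number moves.

The compounds shown leave open whether the loss of the ring or the entry of the oxygen carries the step, a question that an all-carbon propyl group on the same carbonyl carbon would help to separate. They also leave open how this position responds to a longer chain ending in an amine or a carboxylic acid.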